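The compounds below may be only part of what the source reports. "The series", "measured", "known", "first", "only" and "open" are said of these compounds alone.

Working notes on the series. For the measured compounds named here, in a physicochemical assay for lipophilicity, read by HPLC, measured as octanol-water partition (a lower number here means a more polar compound, a higher number a more lipophilic compound), compound 2 `CCN1CCN(C[C@H]2CN(c3ccc(-n4cc(-c5ccccn5)cn4)c(F)c3)C(=O)O2)CC1` gives 2.19, the higher of the two numbers measured so far; compound 1 `CN(CCC#N)C[C@H]1CN(c2ccc(-n3cc(-c4ccccn4)cn3)c(F)c2)C(=O)O1` gives 1.9, and the step of a number 0.29 log units higher from compound 1 to compound 2 (within the scatter) lies within the scatter, so the two stand level. Compound 3 `COC(=O)CC1CCN(C[C@H]2CN(c3ccc(-n4cc(-c5ccccn5)cn4)c(F)c3)C(=O)O2)CC1` has not been measured. It differs from compound 2 by 4-((methoxycarbonyl)methyl)piperidin-1-yl in place of 4-ethylpiperazin-1-yl on a saturated chain carbon bound to a saturated ring carbon. Going by the values given here, the only measured step at this place is a number 0.29 log units higher from compound 1 to compound 2 (within the scatter), an exchange of the group on the saturated chain carbon bound to a saturated ring carbon that moved the number no further than the scatter. The present exchange is larger by count and trades a ring with two hetero atoms for one with one hetero atom, so a small rise in this assay is expected, not far beyond the scatter. For compound 3 the estimated value is 2.5, with a range from 2.1 to 2.9. The expected step is a number 0.31 log units higher from compound 2 to compound 3 (beyond the scatter).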

Compound 3, partition coefficient: 1.78
Compound 3: the middle estimate sits 0.72 log units above what was measured; measured number outside the range, below it.
By their numbers in this assay, from the lowest: compounds 3, 1 and 2 (each within the scatter of the next, the first and the last beyond it).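

In this assay, for the compounds shown here, 4-((methoxycarbonyl)methyl)piperidin-1-yl in place of 4-ethylpiperazin-1-yl gives a number 0.41 log units lower from compound 2 to compound 3 (beyond the scatter), the first step on this saturated chain carbon bound to a saturated ring carbon that passes the scatter, so a change at this place can move the number. The same group in place of (2-cyanoethyl)(methyl)amino gives a number 0.12 log units lower from compound 1 to compound 3 (within the scatter), which leaves these two groups level despite their different make-up. Nothing available accounts for the direction of the step from the ethylpiperazine.

The exchange changes the ring hetero atoms and adds the methyl ester together, so the compounds shown do not separate the two. A 4-ethylpiperidin-1-yl group would isolate the ring change, and a carboxylic acid in place of the methyl ester would test the ester end of the chain.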